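Benzyl ether swap from the limit of compound 2

The compounds below may be only part of what the source reports. "The series", "measured", "known", "first", "only" and "open" are said of these compounds alone.

Compound 2 `COc1cc(OC)c(-c2coc3cc(OCc4ccc([N+](=O)[O-])cc4)ccc3c2=O)cc1OC` gives only a limit in a functional assay on HCT-116 cells (Homo sapiens) for antiproliferative activity, read by MTT assay, with a stated time of 24 h (on this read-out higher numbers stand for weaker inhibition and lower numbers for stronger inhibition), namely > 10000 nM. Compound 1 `COc1cc(OC)c(-c2coc3cc(OCC=C(C)C)ccc3c2=O)cc1OC` stands at 680 nM and compound 3 `COc1cc(OC)c(-c2coc3cc(OCc4cccc(F)c4)ccc3c2=O)cc1OC` at 4920 nM. The change to compound 4 `COc1cc(OC)c(-c2coc3cc(OCc4ccccc4Cl)ccc3c2=O)cc1OC` is 2-chlorophenyl in place of 4-nitrophenyl on a saturated chain carbon bound to an oxygen on an aromatic ring, with 2-chlorophenyl in place of 4-nitrophenyl. The nearest guide is an at least 2.0-fold lower number from compound 2 to compound 3 (0.30 log units; that floor lies within the scatter). Both a 7.2-fold higher number from compound 1 to compound 3 (0.86 log units; beyond the scatter) and an at least 14-fold higher number from compound 1 to compound 2 (1.16 log units; beyond the scatter) argue against a return to the level of compound 1. Compound 4 is therefore expected to sit near compound 3, with a modest move towards lower numbers. The expected change is an at least 2.0-fold lower number from compound 2 to compound 4 (0.30 log units; that floor lies within the scatter). For compound 4 the estimated value is 5000 nM, with an expected range of 1800 nM to 12000 nM.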

Compound 4, half-maximal inhibitory concentration: 2450 nM
Estimate against measurement, compound 4: 2.0-fold (0.31 log units) above, and the stated range covers the measured number.
By their numbers in this assay, from the lowest: compound 1; then compounds 4 and 3 (each within the scatter of the next). At a limit, above all of these: compound 2.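

In this assay compound 2 gives only a limit (> 10000 nM), not a number. Replacing 4-nitrophenyl with 2-chlorophenyl gives a step that clears the scatter (an at least 4.0-fold lower number from compound 2 to compound 4 (0.61 log units; beyond the scatter)), which the floor of the step to compound 3 did not. Compounds 3 and 4 cannot be separated (a 2.0-fold lower number from compound 3 to compound 4 (0.30 log units; within the scatter)), and the 2-chlorobenzyl ether remains short of the level of the 2-methylprop-1-en-1-yl chain (a 3.6-fold higher number from compound 1 to compound 4 (0.56 log units; beyond the scatter)).

The compounds shown do not separate the effect of the substituent from that of its ring position. Open too, from the compounds shown here alone, is whether an amine on the benzyl ring, or a longer chain on the ether oxygen, would reach the level of compound 1.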